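This account rests on a few compounds, and the source may have more. Where it says the series, first, only, none or still open, it means among the compounds named here.

Compound 1 `Cc1cc(NC(=O)Cn2nnc(-c3ccccc3)n2)n(C2CCOCC2)n1`: in an assay on HEK293 cells for activation of Kir3.1/Kir3.2 (Homo sapiens), read by thallium flux (on this read-out lower numbers stand for an effect already at smaller amounts and higher numbers for an effect only at larger amounts of compound), compound 1 gives 435 nM.
Compound 2 `Cc1cc(NC(=O)Cn2nnc(-c3ccccc3)n2)n(C2CC2)n1`: for compound 2 only a limit of this assay is known, > 5000 nM.

On these data alone, compound 2 thus sits at the limit of > 5000 nM in this assay, at which 1 of the 2 values shown sits, and its true number is unknown. Compound 3 `Cc1cc(NC(=O)Cn2nnc(-c3ccccc3)n2)n(C2CCS(=O)(=O)C2)n1` differs from compound 2 by 1,1-dioxothiolan-3-yl in place of cyclopropyl on an aromatic nitrogen. Within the data shown here, the only measured step that bears on this position, an at least 11-fold higher number from compound 1 to compound 2 (1.06 log units; beyond the scatter), shows that replacing oxan-4-yl by cyclopropyl cost a great deal. The entering group, like oxan-4-yl, is a saturated ring carrying hydrogen-bond acceptors, so a gain is expected, of about an at least 3.3-fold lower number from compound 2 to compound 3 (0.52 log units; beyond the scatter), though its size is uncertain. Compound 3 is estimated at 1500 nM, within a range of 300 nM to 6000 nM.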

Compound 3, half-maximal effective concentration: 1030 nM
The estimate for compound 3 lay 1.5-fold (0.16 log units) above the measured number; low and high end bracket the measured number.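

Placing 1,1-dioxothiolan-3-yl on the aromatic nitrogen instead of cyclopropyl gives an at least 4.8-fold lower number from compound 2 to compound 3 (0.68 log units; beyond the scatter), so the loss seen with cyclopropyl does not extend to every replacement of oxan-4-yl. On these data alone, compound 2 is known only as a limit, so the true size of this step remains unknown: the limit of > 5000 nM in this assay, at which 1 of the 3 values shown sits. The recovery is only partial, since 1,1-dioxothiolan-3-yl in place of oxan-4-yl gives a 2.4-fold higher number from compound 1 to compound 3 (0.37 log units; beyond the scatter) in this assay.

As far as these compounds go, it remains open how a plain cyclopentyl ring or a piperidin-4-yl ring, which carries an amine, would fare at this position. Whether the oxygen atoms of the entering rings matter at all also stays unsettled.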